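Moving the amine onto the ring in compound 4

The source may hold more compounds than are shown below. What is called first, only, known or untested is meant among the compounds shown, and "the series" means these compounds.

Three compounds have been measured in an assay on CHO cells for displacement of a labelled ligand from 5-hydroxytryptamine receptor 1D (Homo sapiens); a lower number here means a stronger inhibitor, a higher number a weaker inhibitor:
compound 1 `CC(=O)Nc1ccc([C@H](C)NCC2CCN(CCCc3c[nH]c4ccc(-n5cnnc5)cc34)CC2)cc1` gives 0.6 nM
compound 2 `c1ccc(CNCC2CCN(CCCc3c[nH]c4ccc(-n5cnnc5)cc34)CC2)cc1` gives 1.6 nM
compound 3 `CC(=O)Nc1ccc(CNCC2CCN(CCCc3c[nH]c4ccc(-n5cnnc5)cc34)CC2)cc1` gives 4.2 nM

Compound 2 stands second of the three: its number is lower than that of compound 3, as shown by a 2.6-fold higher number from compound 2 to compound 3 (0.42 log units; beyond the scatter), and higher than that of compound 1, as shown by a 2.7-fold higher number from compound 1 to compound 2 (0.43 log units; beyond the scatter). Compound 4 `CN(Cc1cccs1)C1CCN(CCCc2c[nH]c3ccc(-n4cnnc4)cc23)CC1` differs from compound 2 in this way: methyl((thiophen-2-yl)methyl)amino in place of (benzylamino)methyl on a saturated ring carbon.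

Among the compounds with values here, none of the measured steps touches this place. The steps of a 2.7-fold higher number from compound 1 to compound 2 (0.43 log units; beyond the scatter) and a 2.6-fold higher number from compound 2 to compound 3 (0.42 log units; beyond the scatter) alter the group on the benzyl arm, and a 7.0-fold higher number from compound 1 to compound 3 (0.85 log units; beyond the scatter) adds or removes a methyl on the chain carbon next to the amine nitrogen; all three stay modest. The change to compound 4 is larger, removing the hydrogen-bond donor and bringing the amine onto the ring carbon, so for compound 4 a modest rise in the number is expected, a 3.1-fold higher number from compound 2 to compound 4 (0.49 log units; beyond the scatter), with wide uncertainty. The estimate for compound 4 in this assay is 5 nM, expected to lie between 1.5 nM and 20 nM.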

Compound 4, half-maximal inhibitory concentration: 4.3 nM
Compound 4: middle estimate off by 1.2-fold (0.07 log units), on the high side; low and high end bracket the measured number.
By their numbers in this assay, from the lowest: compound 1; then compound 2; then compounds 3 and 4 (each within the scatter of the next).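

In this assay, within the data shown here, the step of a 2.7-fold higher number from compound 2 to compound 4 (0.43 log units; beyond the scatter) is the first to alter the group on the saturated ring carbon itself, as the earlier steps changed only the benzyl arm or its chain carbon. This single replacement moves the amine onto the ring carbon, swaps the six-membered aromatic ring for a five-membered one with a hetero atom, and removes the hydrogen-bond donor, yet the step remains modest. Nothing measured here explains the size of this step.

Because these changes arrive together, the compounds shown leave open how much of the step belongs to each. As far as these compounds go, it also remains open how the number would respond to a hydrogen in place of the methyl on the amine nitrogen, or to a furan ring in place of the thiophene.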